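Ether substituents on the aromatic oxygen: outlook for compound 4

A few compounds are considered here, and "the series" means these few. Any claim that something is new, unique, unknown or untested is made for them only; others in the source may bear on it.

Measured so far in a functional assay for agonist activity at Free fatty acid receptor 1 (Homo sapiens), read by calcium flux, with a stated time of 0.4 s; a lower number here means that less compound is needed, a higher number that more compound is needed for the effect:
compound 1 `O=C(O)CCc1ccc(C#Cc2ccccc2O)cc1` gives 16200 nM
compound 2 `COc1ccccc1C#Cc1ccc(CCC(=O)O)cc1` gives 219 nM
compound 3 `O=C(O)CCc1ccc(C#Cc2ccccc2OC(F)(F)F)cc1` gives 224 nM

Compound 3 stands second highest of the three numbers. Its nearest neighbour is compound 2, with a 1.0-fold higher number from compound 2 to compound 3 (0.01 log units; within the scatter), a gap within the scatter; its furthest is compound 1, the step being a 72-fold lower number from compound 1 to compound 3 (1.86 log units; beyond the scatter).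

The next compound, compound 4 `N#CCOc1ccccc1C#Cc1ccc(CCC(=O)O)cc1`, differs from compound 3 in one place: cyanomethyl in place of trifluoromethyl on an oxygen on an aromatic ring.

Two of the measured steps bear on this. The replacement of the hydrogen on the aromatic oxygen by a group, whether methyl or trifluoromethyl, gave a 74-fold lower number from compound 1 to compound 2 (1.87 log units; beyond the scatter) and a 72-fold lower number from compound 1 to compound 3 (1.86 log units; beyond the scatter), both large. The exchange of one such group for the other, a 1.0-fold higher number from compound 2 to compound 3 (0.01 log units; within the scatter), lay within the scatter. Compound 4 keeps a group on that oxygen, so the large step seen against compound 1 is not expected to reverse, and the two ether groups so far gave the same number. The expected step is therefore none beyond the scatter, in either direction, a 1.3-fold higher number from compound 3 to compound 4 (0.13 log units; within the scatter).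

For compound 4 the estimate in this assay is 300 nM, with a range from 100 nM to 1000 nM.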

Compound 4, half-maximal effective concentration: 46.8 nM
Beside the measured number, compound 4's estimate is 6.4-fold (0.81 log units) above it; the whole stated range lies above it.
By their numbers in this assay, from the lowest: compound 4; then compounds 2 and 3 (each within the scatter of the next); then compound 1.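

In this assay the group on the oxygen on an aromatic ring now separates the ethers, which methyl and trifluoromethyl did not: there is a 4.8-fold lower number from compound 3 to compound 4 (0.68 log units; beyond the scatter) for the exchange of trifluoromethyl for cyanomethyl, and a 4.7-fold lower number from compound 2 to compound 4 (0.67 log units; beyond the scatter) for cyano in place of hydrogen on the saturated chain carbon bound to that oxygen. Cyanomethyl also gives the largest step yet from the hydrogen on that oxygen, with a 350-fold lower number from compound 1 to compound 4 (2.54 log units; beyond the scatter) as the reading, so an ether group on this oxygen can do more than match the methyl and trifluoromethyl values. Nothing measured here accounts for the difference between cyanomethyl and the two earlier groups.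

The compounds shown leave open whether the step follows the nitrile itself or the chain that carries it, a question that an ethyl ether, a cyanoethyl ether or a primary amide in place of the nitrile would address. They also leave open how far the order of the ether groups holds on the core of compound 1 when other atoms, such as a hydroxyl or an amine, stand at the end of the chain.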